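The source may hold more compounds than are shown below. What is called first, only, known or untested is meant among the compounds shown, and "the series" means these compounds.

In a functional assay on MDA-MB-231 cells (Homo sapiens) for inhibition, read by MTT assay, with a stated time of 48 h (a lower number here means a stronger inhibitor of growth, a higher number a weaker inhibitor of growth), compound 1 `S=C(Nc1ccccc1)Nc1ccc2ncnc(Nc3cccc(Br)c3)c2c1` gives 10000 nM and compound 2 `Oc1ccc(NC(=S)Nc2ccc3ncnc(Nc4cccc(Br)c4)c3c2)cc1` gives 17300 nM. Hydroxy in place of hydrogen leaves these two within the scatter, a 1.7-fold higher number from compound 1 to compound 2 (0.24 log units; within the scatter).

Compound 3 `NS(=O)(=O)c1ccc(NC(=S)Nc2ccc3ncnc(Nc4cccc(Br)c4)c3c2)cc1` gives > 30000 nM, which is a limit and not a number. Among the compounds with values here, the series so far shows (the limit of > 30000 nM in this assay, at which 1 of the 3 values shown sits). Sulfamoyl in place of hydrogen gives an at least 3.0-fold higher number from compound 1 to compound 3 (0.47 log units; beyond the scatter), which is beyond the scatter. Sulfamoyl in place of hydroxy gives an at least 1.7-fold higher number from compound 2 to compound 3 (0.23 log units; that floor lies within the scatter), whose floor lies within the scatter.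

Compound 4 `Fc1ccc(NC(=S)Nc2ccc3ncnc(Nc4cccc(Br)c4)c3c2)cc1Cl` carries 3-chloro-4-fluorophenyl in place of 4-sulfamoylphenyl on an amide-type nitrogen. Within the data shown here, no measured compound carries chlorine or fluorine, so the effect of the incoming ring is not covered by any step so far. The nearest guide is an at least 3.0-fold higher number from compound 1 to compound 3 (0.47 log units; beyond the scatter), read in reverse: with the sulfamoyl gone, a return towards the level of compound 1 at 10000 nM is expected. The size of that return is uncertain, since compound 3 has only a limit to start from. The expected move in this assay is to a lower number, beyond the scatter, as the estimated at least 3.3-fold lower number from compound 3 to compound 4 (0.52 log units; beyond the scatter). For compound 4 the expected value is 9000 nM, with an estimated range from 3000 nM to 25000 nM.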

Compound 4, concentration for 50% growth inhibition: 300 nM
The estimate for compound 4 lay 30-fold (1.48 log units) above the measured number, outside the stated range (below it).
By their numbers in this assay, from the lowest: compound 4; then compounds 1 and 2 (each within the scatter of the next). At a limit, above all of these: compound 3.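

In this assay, within the data shown here, the ring on the amide-type nitrogen proves able to move the number by far more than the earlier compounds showed: 3-chloro-4-fluorophenyl in place of phenyl gives a 33-fold lower number from compound 1 to compound 4 (1.52 log units; beyond the scatter), whereas hydroxy in place of hydrogen stayed within the scatter. The same ring in place of 4-hydroxyphenyl gives a 58-fold lower number from compound 2 to compound 4 (1.76 log units; beyond the scatter), and in place of 4-sulfamoylphenyl it gives an at least 100-fold lower number from compound 3 to compound 4 (2.00 log units; beyond the scatter), so every step to compound 4 is large and compound 4 is the strongest inhibitor of growth among the compounds shown. The step from compound 3 is only a floor, as compound 3 stands at a limit and not at a number: the limit of > 30000 nM in this assay, at which 1 of the 4 values shown sits.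

The compounds shown do not separate the contribution of the chlorine from that of the fluorine, so it remains open whether either halogen alone on the phenyl ring would account for the large step. On these data alone, it also remains open whether a methyl, a methoxy or an amine on that ring would give a similar number, and whether the gain holds with a carbonyl in place of the thiocarbonyl.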